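Anilino-enaminone series: amino for fluoro on the aryloxy ring

A few compounds are considered here, and "the series" means these few. Any claim that something is new, unique, unknown or untested is made for them only; others in the source may bear on it.

Measured compounds:
Compound 1 `CC(Nc1ccccc1Oc1cccc(F)c1)=C1C(=O)CC(c2ccccc2)CC1=O` — 360 nM
Compound 2 `CCOc1ccccc1NC(C)=C1C(=O)CC(c2ccccc2)CC1=O` — 100 nM

Both compounds share a core and were tested in a functional assay on HMEC-1 cells (Homo sapiens) for antiproliferative activity, read by cell counting, with a stated time of 4 days; on this read-out higher numbers stand for weaker inhibition and lower numbers for stronger inhibition. Compound 1 gives 360 nM and stands highest of the two numbers; compound 2 gives 100 nM, and the step of a 3.6-fold lower number from compound 1 to compound 2 (0.56 log units; beyond the scatter) came with ethyl in place of 3-fluorophenyl on the oxygen.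

Compound 3 `CC(Nc1ccccc1Oc1cccc(N)c1)=C1C(=O)CC(c2ccccc2)CC1=O` is not yet measured. Relative to compound 1 it carries amino in place of fluoro on an aromatic carbon, the change sitting meta to a large group on the aryloxy ring. Within the data shown here, no measured step touches the substituent on that ring: the single step known, from compound 1 to compound 2, replaces the whole 3-fluorophenyl group and does not inform a fluoro-to-amino exchange within it. With nothing to point either way, no step beyond the scatter is expected.

Compound 3 is therefore estimated at 320 nM, within 110 nM to 950 nM, which means an expected step of a 1.1-fold lower number from compound 1 to compound 3 (0.05 log units; within the scatter).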

Compound 3, half-maximal inhibitory concentration: 41 nM
Compound 3: the middle estimate sits 7.8-fold (0.89 log units) above what was measured; measured number outside the range, below it.
By their numbers in this assay, from the lowest: compound 3; then compound 2; then compound 1.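

In this assay the exchange of fluoro for amino on an aromatic carbon, meta to a large group, gives an 8.8-fold lower number from compound 1 to compound 3 (0.94 log units; beyond the scatter) and so shows that this single substituent matters, which the earlier replacement of the whole 3-fluorophenyl group could not reveal. The comparison with ethyl on the oxygen also changes: a 3.6-fold lower number from compound 1 to compound 2 (0.56 log units; beyond the scatter) favoured ethyl over 3-fluorophenyl, whereas a 2.4-fold lower number from compound 2 to compound 3 (0.39 log units; beyond the scatter) favours 3-aminophenyl over ethyl, so the outcome depends on what the phenyl ring carries. The data available offer no explanation for the effect of the amino group.

Going by these compounds, it remains open whether this step is particular to the amino group or would also appear with a hydroxyl, a methylamino or an acetamido group in the same place. A carboxylic acid there would test the limits of the change further.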